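Ethoxy to methoxy on the shared core: half-life outlook

This account rests on a few compounds, and the source may have more. Where it says the series, first, only, none or still open, it means among the compounds named here.

For the measured compounds named here, compound 3 `CCOc1cc(OC)ccc1C[S+]([O-])c1ncccc1C(=O)Nc1ccncc1` gives 0.71 h in an ADME assay (on this read-out higher numbers stand for a longer-lived compound and lower numbers for a shorter-lived compound), the lowest of the three numbers so far. Compound 2 `COc1ccc(C[S+]([O-])c2ncccc2C(=O)Nc2ccncc2)c(OCCF)c1` gives 3.3 h in this assay, and compound 1 `COc1ccc(C[S+]([O-])c2ncccc2C(=O)Nc2ccncc2)c(OC)c1OC` gives 116 h in this assay, far above the other two. Going by the values given here, the only step between compounds differing in one place is a 4.6-fold lower number from compound 2 to compound 3 (0.67 log units; beyond the scatter), which shows that a small change on the chain carried by the aromatic oxygen can move this assay beyond the scatter. Compound 4 `COc1ccc(C[S+]([O-])c2ncccc2C(=O)Nc2ccncc2)c(OC)c1` is compound 3 with hydrogen in place of methyl on a saturated chain carbon bound to an oxygen on an aromatic ring, read one bond further out as ethoxy to methoxy. Among the compounds with values here, no measured step covers this change; compound 1 and compound 4 differ in more than one place, so their comparison only shows that compound 1 stands much higher than compound 3. Given the direction of the step from compound 2 to compound 3, a modest rise is expected for compound 4, a 2.1-fold higher number from compound 3 to compound 4 (0.32 log units; beyond the scatter), with wide uncertainty. Compound 4 is estimated at 1.5 h, range 0.4 h to 6 h.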

Compound 4, half-life: 0.84 h
Beside the measured number, compound 4's estimate is 1.8-fold (0.25 log units) above it; the range from low to high includes it.
By their numbers in this assay, from the lowest: compounds 3 and 4 (each within the scatter of the next); then compound 2; then compound 1.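

Ethoxy to methoxy on a saturated chain carbon bound to an oxygen on an aromatic ring gives a 1.2-fold higher number from compound 3 to compound 4 (0.07 log units; within the scatter) in this assay, so this change does not separate the two chains on this read-out. Hydrogen in place of fluoromethyl at the same place gives a 3.9-fold lower number from compound 2 to compound 4 (0.59 log units; beyond the scatter), which sets the fluoro-bearing chain apart from both the ethoxy and the methoxy chain. The largest new step is hydrogen in place of methoxy on an aromatic carbon, with a 140-fold lower number from compound 1 to compound 4 (2.14 log units; beyond the scatter), so that change on the ring outweighs the chain changes seen so far.

No measurement available here explains any of these steps. As far as these compounds go, how a longer chain such as propoxy, or an amine carried on that chain, would read in this assay remains open.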